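A few compounds are considered here, and "the series" means these few. Any claim that something is new, unique, unknown or untested is made for them only; others in the source may bear on it.

Of the compounds shown here, two built on one shared core have been measured so far. In a functional assay on NCI-H460 cells (Homo sapiens) for inhibition, read by sulforhodamine B assay, with a stated time of 48 h, tested at 10 uM (a higher number here means a weaker effect of the compound at the concentration tested, a lower number a stronger effect), compound 1 `COc1cc(Cl)cc(-c2nn(-c3cccc(NC(=O)c4ccc(Cl)c(Cl)c4)c3)cc2-c2ccncc2)c1` gives 65.2%. In this assay compound 2 `COc1cc(Cl)cc(-c2nn(-c3cccc(NC(=O)Nc4cc(C(F)(F)F)cc(C(F)(F)F)c4)c3)cc2-c2ccncc2)c1` gives 0.24%, the lowest of the two numbers, and compound 1 stands far higher, by a gap beyond the usual scatter.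

Compound 3 `COc1cc(Cl)cc(-c2nn(-c3cccc(NC(=O)Nc4cccc(C(F)(F)F)c4)c3)cc2-c2ccncc2)c1` has not yet been measured. It differs from compound 2 in one place: hydrogen in place of trifluoromethyl on an aromatic carbon. Among the compounds with values here, no step between measured compounds that differ in one place is available, so the data give no direct guide to the size of this change. Compound 2 gives 0.24%, a strong effect, and a loss of one trifluoromethyl group is expected to weaken the effect, so the expected step is a number 19.8 percentage points higher from compound 2 to compound 3 (beyond the scatter) in this assay, upward. Compound 3 is estimated at 20%, within a range from 2% to 55%.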

Compound 3, a percentage reported as activity, at one concentration (the size of the read-out at that concentration, not a potency): -6.11%
For compound 3 the middle estimate is 26.1 percentage points above the measured one, and the stated range ends above it.
By their numbers in this assay, from the lowest: compounds 3 and 2 (each within the scatter of the next); then compound 1.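

In this assay the second trifluoromethyl group is not needed for the effect at the concentration tested: hydrogen in its place gives a number 6.4 percentage points lower from compound 2 to compound 3 (within the scatter) and leaves compound 2 and compound 3 indistinguishable. The large gap to the amide compound 1 persists with a single trifluoromethyl group, as (3-(trifluoromethyl)phenyl)amino in place of 3,4-dichlorophenyl on a carbonyl carbon gives a number 71.3 percentage points lower from compound 1 to compound 3 (beyond the scatter) in this assay. No measurement at hand bears on why either step has this size.

From the compounds shown here alone, it remains open whether the remaining trifluoromethyl group is itself required, or whether hydrogen, a nitrile or an amine could take its place on that aromatic ring with the effect retained. Also open, going by these compounds, is how compound 2 and compound 3 compare at concentrations lower than the one tested.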